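A methyl for a nitrile on the benzyl arm

The compounds below may be only part of what the source reports. "The series", "measured", "known", "first", "only" and "open" are said of these compounds alone.

Compounds measured so far in a functional assay on NIH3T3 cells (Mus musculus); a higher number here means that more compound is needed for the effect, a lower number that less compound is needed:
- compound 1 `COC(=O)[C@H](CCSC)NC(=O)c1ccc(NCc2cncn2Cc2ccc(C#N)cc2)cc1-c1ccccc1`: > 10 uM
- compound 2 `N#Cc1ccc(Cn2cncc2CNc2ccc(C(=O)NCc3ccccc3)c(-c3ccccc3)c2)cc1`: > 10 uM
- compound 3 `CSCC[C@H](NC(=O)c1ccc(NCc2cncn2Cc2ccc(C#N)cc2)cc1-c1ccccc1)C(=O)O`: > 10 uM

In this assay compound 1 gives > 10 uM, which is a limit of the assay rather than a measured number. Compound 2 gives > 10 uM, again only a limit. Compound 3 gives > 10 uM, also a limit. As far as these compounds go, because all three values sit at the limit of > 10 uM in this assay, at which 3 of the 3 values shown sit, none of the steps between them can be read: a step that the two limits leave unreadable from compound 1 to compound 2, a step that the two limits leave unreadable from compound 1 to compound 3 and a step that the two limits leave unreadable from compound 2 to compound 3 all remain open in size and direction.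

Compound 4 `COC(=O)[C@H](CCSC)NC(=O)c1ccc(NCc2cncn2Cc2cccc(C)c2)cc1-c1ccccc1` differs from compound 1 in one place: 3-methylphenyl in place of 4-cyanophenyl on a saturated chain carbon bound to an aromatic nitrogen. Going by the values given here, no measured step touches this part of the molecule, and the three measured compounds all carry the same 4-cyanobenzyl group, so the measured data give no guide to the size or direction of the change. With compound 1 itself standing only at a limit, the most likely outcome for compound 4 is expected to be another limit, with a step that the limit leaves unreadable from compound 1 to compound 4 expected to be small if a number does emerge. Compound 4 is therefore estimated at 15 uM, within a range from 4 uM to 60 uM.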

Compound 4, concentration for half-maximal effect: > 10 uM
Compound 4: only a limit was reported; the forecaster's own chance of this, stated with the estimate: 75%; the middle value lies beyond the limit too.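

In this assay compound 4 gives > 10 uM, which is a limit and not a number. The step from compound 1 to compound 4 cannot be read, because the values share one limit: the limit of > 10 uM in this assay, at which 4 of the 4 values shown sit.

The compounds shown leave open whether 4-cyanobenzyl or 3-methylbenzyl serves better.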